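Nitrone series: benzyl against tert-butyl on two chains

A few compounds are considered here, and "the series" means these few. Any claim that something is new, unique, unknown or untested is made for them only; others in the source may bear on it.

Compound 1 `CCCCCCCCn1cc(/C=[N+](\[O-])Cc2ccccc2)nn1` and compound 2 `[O-]/[N+](=C\c1cn(CCC(F)(F)C(F)(F)C(F)(F)C(F)(F)C(F)(F)C(F)(F)F)nn1)Cc1ccccc1` both carry a benzyl group on the nitrone nitrogen; the difference between their two cores is not broken down here. In a functional assay on PC-3 cells (Homo sapiens) for inhibition, read by MTT assay, with a stated time of 24 h (on this read-out higher numbers stand for weaker inhibition and lower numbers for stronger inhibition), compound 1 reaches only the limit of > 100000 nM. Compound 2 likewise sits at the limit of > 100000 nM in this assay, so only a bound is known for it. Compound 3 `CCCCCCCCn1cc(/C=[N+](\[O-])C(C)(C)C)nn1` differs from compound 1 by tert-butyl in place of benzyl on a double-bonded nitrogen. In this assay compound 3 gives 24600 nM, a step of an at least 4.0-fold lower number from compound 1 to compound 3 (0.60 log units; beyond the scatter). That step is only bounded: the limit of > 100000 nM in this assay, at which 2 of the 3 values shown sit, is all that is known of compound 1. Compound 4 `CC(C)(C)/[N+]([O-])=C/c1cn(CCC(F)(F)C(F)(F)C(F)(F)C(F)(F)C(F)(F)C(F)(F)F)nn1` is not yet measured; it differs from compound 2 by tert-butyl in place of benzyl on a double-bonded nitrogen, the same change at the same place. From compound 2 to compound 4 a step of an at least 2.8-fold lower number from compound 2 to compound 4 (0.45 log units; beyond the scatter) is expected, resting on the step of an at least 4.0-fold lower number from compound 1 to compound 3 (0.60 log units; beyond the scatter) shown by compound 3. The expected value for compound 4 in this assay is 35000 nM, between 10000 nM and 100000 nM.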

Compound 4, half-maximal inhibitory concentration: 11200 nM
For compound 4 the middle estimate is 3.1-fold (0.49 log units) above the measured one; the measured number falls inside the stated range.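

In this assay, tert-butyl in place of benzyl on a double-bonded nitrogen gives an at least 8.9-fold lower number from compound 2 to compound 4 (0.95 log units; beyond the scatter), the same direction as on the core of compound 1. The direction therefore holds in both pairs shown, but whether the size of the change carries over stays unsettled: the same change on two cores in this assay, an at least 4.0-fold lower number (0.60 log units; beyond the scatter) from compound 1 to compound 3 and an at least 8.9-fold lower number (0.95 log units; beyond the scatter) from compound 2 to compound 4; the limit leaves it open whether they differ Compound 1 and compound 2 each stand at a limit and not at a number, so both steps are bounds only: the limit of > 100000 nM in this assay, at which 2 of the 4 values shown sit.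

Two pairs cannot show how the change behaves on other cores. Also open, going by these compounds, is whether an isopropyl group, a cyclohexyl group or a benzyl group bearing an amine or a carboxylic acid on the same nitrogen would give numbers closer to those with tert-butyl or to the benzyl limits.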